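The compounds below may be only part of what the source reports. "The series", "measured", "known", "first", "only" and "open" are said of these compounds alone.

Compound 1 `CN(Cc1nc2cccc(CNCCN)c2[nH]1)C1CCCc2cccnc21`: > 20000 nM
Compound 2 `CN(Cc1nc2cccc(CCCN)c2[nH]1)C1CCCc2cccnc21`: 10000 nM

In an ADME assay on HOS cells (Homo sapiens) for cytotoxicity (a lower number here means that less compound is tolerated, a higher number that more compound is tolerated), compound 1 gives > 20000 nM, which is a limit of the assay and not a number. For the measured compounds named here, that leaves compound 2, at 10000 nM, as the only true number so far. Compound 3 `CN(C)CCCc1cccc2nc(CN(C)C3CCCc4cccnc43)[nH]c12` has dimethylamino in place of amino on a saturated chain carbon, three bonds along the chain from an aromatic carbon. Going by the values given here, the one measured step, an at least 2.0-fold lower number from compound 1 to compound 2 (0.30 log units; that floor lies within the scatter), is a different change and offers only weak guidance. No shift beyond the scatter is therefore expected in this assay, and the estimated change is no change at the digits printed from compound 2 to compound 3 (within the scatter). For compound 3 the expected value is 10000 nM, with an estimated range of 4000 nM to 20000 nM.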

Compound 3, half-maximal cytotoxic concentration: 7500 nM
Compound 3: the middle estimate sits 1.3-fold (0.12 log units) above what was measured, within the range that was stated.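

In this assay, dimethylamino in place of amino on a saturated chain carbon, three bonds along the chain from an aromatic carbon, gives a 1.3-fold lower number from compound 2 to compound 3 (0.12 log units; within the scatter), so compound 2 and compound 3 cannot be told apart. Compound 1 gives > 20000 nM, which is a limit of the assay and not a number. Even so, an at least 2.6-fold lower number from compound 1 to compound 3 (0.42 log units; beyond the scatter) is the first step here to pass the scatter.

On these data alone, the full size of that step stays open because of the limit: the limit of > 20000 nM in this assay, at which 1 of the 3 values shown sits. Whether a piperidine or an acetamide at the chain end would move the number also remains open.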